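Lengthening the chain: from compound 2 to compound 4

The compounds below may be only part of what the source reports. "The series", "measured", "known", "first", "only" and "open" are said of these compounds alone.

Values measured in a functional assay on KB cells (Homo sapiens) for cytotoxicity, read by resazurin assay, with a stated time of 3 days (on this read-out lower numbers stand for stronger inhibition and higher numbers for weaker inhibition), follow.
Compound 1 `CCCCCCC(=O)NCC(C)(C)CC1=C(O)C(=O)c2ccccc2C1=O` gives 28200 nM
Compound 2 `CCCCCCCCC(=O)NCC(C)(C)CC1=C(O)C(=O)c2ccccc2C1=O` gives 19700 nM
Compound 3 `CCCCCCCCCCC(=O)NCC(C)(C)CC1=C(O)C(=O)c2ccccc2C1=O` gives 17600 nM

Compound 2 at 19700 nM lies within the scatter of both other compounds. The change to compound 4 `CCCCCCCCCCCCCCCCCC(=O)NCC(C)(C)CC1=C(O)C(=O)c2ccccc2C1=O` is nonyl in place of hydrogen on a saturated chain carbon, eight bonds along the chain from a carbonyl carbon on the shared core. The measured steps that bear on it are smaller additions to the same chain. They are a 1.4-fold lower number from compound 1 to compound 2 (0.16 log units; within the scatter) and a 1.6-fold lower number from compound 1 to compound 3 (0.20 log units; within the scatter) and a 1.1-fold lower number from compound 2 to compound 3 (0.05 log units; within the scatter) and all stay within the scatter. The nonyl addition goes well beyond these, so the expectation is loose. In this assay no step beyond the scatter is expected, and the estimated step is a 1.3-fold lower number from compound 2 to compound 4 (0.12 log units; within the scatter) (a slightly lower number, if any change). Compound 4 is estimated at 15000 nM (expected range 6000 nM to 35000 nM).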

Compound 4, half-maximal inhibitory concentration: 6350 nM
Compound 4: middle estimate off by 2.4-fold (0.37 log units), on the high side; measured number inside the range.
By their numbers in this assay, from the lowest: compound 4; then compounds 3, 2 and 1 (each within the scatter of the next).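

In this assay, this chain position now gives steps beyond the scatter, all modest: nonyl in place of hydrogen gives a 3.1-fold lower number from compound 2 to compound 4 (0.49 log units; beyond the scatter), heptyl gives a 2.8-fold lower number from compound 3 to compound 4 (0.44 log units; beyond the scatter), and undecyl gives a 4.4-fold lower number from compound 1 to compound 4 (0.65 log units; beyond the scatter). The shorter chains of compound 1, compound 2 and compound 3 stayed within the scatter of one another, so the lengthening separates only at compound 4. Nothing measured here accounts for this result.

Open, on these data alone, is whether a longer chain lowers the number further or reverses the step. Also open, as far as these compounds go, is whether an amine or a carboxylic acid on this chain would keep it.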